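Removing the 2-carboxyethyl arm of the diacid compound 3

A few compounds are considered here, and "the series" means these few. Any claim that something is new, unique, unknown or untested is made for them only; others in the source may bear on it.

Three compounds have numbers in a functional assay on the whole organism (Tail, strain ICR) with Mus musculus as the target, in the tail flick test, with a stated time of 150 min, at a dose of 25 umol/kg by the oral route; on this read-out higher numbers stand for a stronger effect at the one dose given and lower numbers for a weaker effect. Compound 3 `O=C(O)CC[C@H](NC(=O)CN(c1nc(Cl)nc2[nH]cnc12)C1CC1)C(=O)O` stands highest: in this assay compound 3 gives 29.5%. Compound 1 `NCCCC[C@H](NC(=O)CN(c1nc(Cl)nc2[nH]cnc12)C1CC1)C(=O)OCc1ccccc1` gives 9.88% and compound 2 `O=C(CN(c1ncnc2c1ncn2C1CCCCO1)C1CC1)NCC(=O)OCc1ccccc1` gives 7.26%, both below compound 3 by more than the usual scatter. Compound 4 `O=C(O)CNC(=O)CN(c1nc(Cl)nc2[nH]cnc12)C1CC1` is drawn from compound 3 by one change: hydrogen in place of 2-carboxyethyl on a saturated chain carbon bound to an amide-type nitrogen and a carbonyl carbon. Within the data shown here, no pair of measured compounds differs by a single change, so the size of this step has no direct precedent. Among the measured compounds shown here, compound 3 holds the only value clearly above the two esters, and compound 4 keeps its free acid; the expected step is a number 9.5 percentage points lower from compound 3 to compound 4 (within the scatter), a modest drop that may still fall within the scatter. Compound 4 is estimated at 20%, between 6% and 36%.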

Compound 4, a percentage reported as activity, at one dose (the size of the read-out at that dose, not a potency): 9.08%
The estimate for compound 4 lay 10.9 percentage points above the measured number; measured number inside the range.
By their numbers in this assay, from the lowest: compounds 2, 4 and 1 (each within the scatter of the next); then compound 3.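

Here the arm counts in this assay: hydrogen in place of 2-carboxyethyl gives a number 20.4 percentage points lower from compound 3 to compound 4 (beyond the scatter), the first single-change step in the series. The carboxylic acid that remains in compound 4 therefore does not alone hold the number of compound 3 at this dose. Nothing available explains the drop. Still open, going by these compounds, is whether the terminal carboxylic acid of the arm or its carbon chain carries the effect; a propyl chain or a methyl group on this carbon would separate the two.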